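The source may hold more compounds than are shown below. What is called first, only, known or untested is meant among the compounds shown, and "the series" means these compounds.

Working notes on the series.

Compound 1 `COC(=O)[C@@]1(C)CCC=C2[C@@H]1CC[C@@H](C)[C@]2(C)Cc1c[nH]c2c(C)cccc12` is the reference point; in a functional assay on T47D cells (Homo sapiens) for inhibition, read by sulforhodamine B assay, with a stated time of 48 h (on this read-out higher numbers stand for weaker inhibition of growth and lower numbers for stronger inhibition of growth), compound 1 gives 18000 nM. Compound 2 `COC(=O)[C@@]1(C)CCC=C2[C@@H]1CC[C@@H](C)[C@]2(C)Cc1c[nH]c2c(Br)cccc12` differs from compound 1 by bromo in place of methyl on an aromatic carbon and in this assay compound 2 gives 24000 nM; the step is a 1.3-fold higher number from compound 1 to compound 2 (0.12 log units; within the scatter). Compound 3 `COC(=O)[C@@]1(C)CCC=C2[C@@H]1CC[C@@H](C)[C@]2(C)Cc1c(C)[nH]c2ccc(C)cc12` carries a different core; the difference between the core of compound 3 and that of compound 1 is not broken down here. In this assay compound 3 gives 31000 nM, which sits within the scatter of both compound 1 and compound 2, so no order among the three is claimed.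

Compound 4 `COC(=O)[C@@]1(C)CCC=C2[C@@H]1CC[C@@H](C)[C@]2(C)Cc1c(C)[nH]c2ccc(Br)cc12` has not been measured. It differs from compound 3 by bromo in place of methyl on an aromatic carbon. This is the same kind of change as that from compound 1 to compound 2, but not the same: there the bromo sits ortho to a fused ring and meta to a fused ring, here meta to a fused ring and para to a fused ring. Because the earlier step on compound 1 was a 1.3-fold higher number from compound 1 to compound 2 (0.12 log units; within the scatter), the expectation for compound 4 in this assay is a step of similar size, a 1.2-fold higher number from compound 3 to compound 4 (0.09 log units; within the scatter). Compound 4 is therefore estimated at 38000 nM, with a range from 16000 nM to 90000 nM.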

Compound 4, concentration for 50% growth inhibition: 16000 nM
Beside the measured number, compound 4's estimate is 2.4-fold (0.38 log units) above it; the range from low to high includes it.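

In this assay, bromo in place of methyl on an aromatic carbon gives a 1.9-fold lower number from compound 3 to compound 4 (0.29 log units; within the scatter), so on this second core the change again stays inside the usual scatter. Set beside the step on the core of compound 1, the two results cannot be told apart: the same change on two cores in this assay, a 1.3-fold higher number (0.12 log units; within the scatter) from compound 1 to compound 2 and a 1.9-fold lower number (0.29 log units; within the scatter) from compound 3 to compound 4, 2.6-fold (0.41 log units) apart, within the scatter of two such steps. Going by these compounds alone, this shows no sign that the outcome of the change depends on the core, but it does not show that the change carries over unaltered, as only two steps are available, neither can be read as a real shift, and the bromo does not stand in the same place on the two cores.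

As far as these compounds go, all four compounds share the methyl ester and sit within a narrow band of values, so it remains open whether any change can move the number beyond the scatter. A carboxylic acid in place of the methyl ester, or an amine or a longer chain in place of the methyl or bromo on the aromatic carbon, would address that question.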